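The compounds below may be only part of what the source reports. "The series", "measured", "known", "first", "only" and "open" are said of these compounds alone.

Compound 3 `Cc1cccc(NS(=O)(=O)c2ccc(N3CCNC3=O)cc2)c1` is measured in a functional assay on M21 cells (Homo sapiens) for antiproliferative activity, read by sulforhodamine B assay, with a stated time of 48 h (a lower number here means a stronger inhibitor, a higher number a weaker inhibitor), and gives 69 nM. Among the three compounds measured, compound 3 stands second highest; its nearest neighbour is compound 1 `COc1cccc(NS(=O)(=O)c2ccc(N3CCNC3=O)cc2)c1`, which in this assay gives 65 nM, and its furthest is compound 2 `Cc1cccc(NS(=O)(=O)c2ccc(N3CCNC3=O)cc2)c1C`, which gives 110 nM. Both gaps, a 1.1-fold higher number from compound 1 to compound 3 (0.03 log units; within the scatter) and a 1.6-fold lower number from compound 2 to compound 3 (0.20 log units; within the scatter), lie within the scatter, as does a 1.7-fold higher number from compound 1 to compound 2 (0.23 log units; within the scatter).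

Compound 4 `Cc1ccc(C)c(NS(=O)(=O)c2ccc(N3CCNC3=O)cc2)c1` has not yet been measured. It differs from compound 3 by methyl in place of hydrogen on an aromatic carbon, so that a 3-methylphenyl becomes a 2,5-dimethylphenyl on the sulfonamide nitrogen. Going by the values given here, the step that bears most directly on this is the one from compound 2 to compound 3, where a methyl on the same ring was removed and the number fell only a little, a 1.6-fold lower number from compound 2 to compound 3 (0.20 log units; within the scatter), within the scatter. Read the other way, adding a methyl to that ring did not move the number beyond the scatter. Compound 4 is therefore expected to show a step of a 1.3-fold higher number from compound 3 to compound 4 (0.12 log units; within the scatter), a small rise not beyond the scatter. The estimate for compound 4 in this assay is 90 nM, with a range from 45 nM to 180 nM.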

Compound 4, half-maximal inhibitory concentration: 27 nM
Compound 4: middle estimate off by 3.3-fold (0.52 log units), on the high side; the whole stated range lies above it.
By their numbers in this assay, from the lowest: compound 4; then compounds 1, 3 and 2 (each within the scatter of the next).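

Within this assay the added methyl, ortho to a large group and para to a methyl group, gives the first step on this ring that goes beyond the scatter (a 2.6-fold lower number from compound 3 to compound 4 (0.41 log units; beyond the scatter)), and compound 4 also separates from the methoxy-bearing compound (a 2.4-fold lower number from compound 1 to compound 4 (0.38 log units; beyond the scatter)). So a second methyl does not leave the number unchanged in every arrangement: compound 2 and compound 4 both carry two methyl groups, yet the 2,5-dimethylphenyl stands apart from the 2,3-dimethylphenyl (a 4.1-fold lower number from compound 2 to compound 4 (0.61 log units; beyond the scatter)). No measurement shown accounts for this difference.

The compounds shown leave open whether the methyl ortho to the large group would have the same effect without the methyl para to it. They also leave open how an ethyl group or an amine would read at that carbon.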